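Bromine on the benzyl arm of a triazole series

The compounds below may be only part of what the source reports. "The series", "measured", "known", "first", "only" and "open" are said of these compounds alone.

Compound 1 `O=[N+]([O-])c1ccccc1CSc1nnc(-c2ccc3c(c2)OCCO3)n1-c1ccccc1` is measured in a functional assay on BGC-823 cells (Homo sapiens) for antiproliferative activity, read by MTT assay, with a stated time of 24 h (on this read-out higher numbers stand for weaker inhibition and lower numbers for stronger inhibition), where compound 1 gives 26500 nM. That is the lowest of the two numbers shown; compound 2 `Clc1cccc(CSc2nnc(-c3ccc4c(c3)OCCO4)n2-c2ccccc2)c1` gives 51200 nM in this assay, and the change a 1.9-fold higher number from compound 1 to compound 2 (0.29 log units; within the scatter) stays within the scatter. For compound 3 `Brc1ccccc1CSc1nnc(-c2ccc3c(c2)OCCO3)n1-c1ccccc1` this assay reports only a limit, > 100000 nM. The step of an at least 3.7-fold higher number from compound 1 to compound 3 (0.57 log units; beyond the scatter) therefore rests on that limit (the limit of > 100000 nM in this assay, at which 1 of the 3 values shown sits), as does an at least 1.9-fold higher number from compound 2 to compound 3 (0.29 log units; that floor lies within the scatter).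

Compound 4 `Brc1cccc(CSc2nnc(-c3ccc4c(c3)OCCO4)n2-c2ccccc2)c1` has not been measured. It differs from compound 1 in one place: 3-bromophenyl in place of 2-nitrophenyl on a saturated chain carbon bound to a sulfur. Among the measured compounds shown here, two measured steps bear on this. Removing the nitro in favour of a halogen placed as in compound 2 cost little, while exchanging nitro for bromo on the aromatic carbon, as in compound 3, cost at least a modest amount. A bromo placed like the chloro of compound 2 is expected to land between those outcomes, weaker than compound 1 and with a real chance of a limit.

The estimate for compound 4 is 60000 nM, between 25000 nM and 150000 nM, and the expected step is a 2.3-fold higher number from compound 1 to compound 4 (0.35 log units; beyond the scatter).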

Compound 4, half-maximal inhibitory concentration: 65600 nM
Compound 4: middle estimate off by 1.1-fold (0.04 log units), on the low side, and the stated range covers the measured number.
By their numbers in this assay, from the lowest: compounds 1, 2 and 4 (each within the scatter of the next, the first and the last beyond it). At a limit, above all of these: compound 3.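

In this assay, exchanging the chloro for a bromo gives a 1.3-fold higher number from compound 2 to compound 4 (0.11 log units; within the scatter), so the two halogens cannot be told apart at this place. With 3-bromophenyl in place of 2-nitrophenyl on a saturated chain carbon bound to a sulfur, the change is a 2.5-fold higher number from compound 1 to compound 4 (0.39 log units; beyond the scatter), which gives this series its first fully measured step beyond the scatter from the 2-nitrobenzyl arm. The step of an at least 1.5-fold lower number from compound 3 to compound 4 (0.18 log units; that floor lies within the scatter) rests on a limit, and its size cannot be read: the limit of > 100000 nM in this assay, at which 1 of the 4 values shown sits.

The compounds shown leave open whether the gain in compound 1 belongs to the nitro itself or to where it sits. They also leave open how an amine or a carboxylic acid on the benzyl arm would read in this assay.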